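The source may hold more compounds than are shown below. What is called first, only, known or untested is meant among the compounds shown, and "the series" means these compounds.

Of the compounds shown here, two with the same core have been measured so far. Compound 1 `COc1cc(C(=O)c2cn(-c3ccccc3)cc2-c2cccc(Br)c2)cc(OC)c1OC` gives 950 nM in a functional assay on MCF7 cells (Homo sapiens) for cytotoxicity, read by MTT assay, with a stated time of 96 h; on this read-out higher numbers stand for weaker inhibition and lower numbers for stronger inhibition. Among the compounds with values here, compound 2 `COc1cc(C(=O)c2cn(-c3ccccc3)cc2-c2ccc([N+](=O)[O-])cc2)cc(OC)c1OC` gives 590 nM in this assay, the lower of the two numbers, and the only step measured is a 1.6-fold lower number from compound 1 to compound 2 (0.21 log units; within the scatter), so the two compounds cannot be told apart on these data.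

Compound 3 `COc1cc(C(=O)c2cn(-c3ccccc3)cc2/C=C/c2ccccc2)cc(OC)c1OC` is the next one to be measured. It differs from compound 2 in one place: 2-phenylethenyl in place of 4-nitrophenyl on an aromatic carbon. Within the data shown here, the single measured step, from compound 1 to compound 2, swaps one aromatic group for another at this same position and stays within the scatter; it gives no direct guide to a 2-phenylethenyl group, which has not been tried here. Among the measured compounds shown here, with only that step to go on, the expectation for compound 3 in this assay is a number close to that of compound 2, with no step beyond the scatter foreseen, though the wide range reflects how little is known about this change. The step expected is a 1.2-fold higher number from compound 2 to compound 3 (0.07 log units; within the scatter). Compound 3 is estimated at 700 nM, within a range of 250 nM to 2000 nM.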

Compound 3, half-maximal inhibitory concentration: 2200 nM
Compound 3: middle estimate off by 3.1-fold (0.50 log units), on the low side; the measured number lies above the stated range.
By their numbers in this assay, from the lowest: compounds 2 and 1 (each within the scatter of the next); then compound 3.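

The two aromatic groups compared earlier, 3-bromophenyl and 4-nitrophenyl, could not be told apart at this position on the five-membered aromatic ring, so that pair gave no sign that the position responds to what is placed on it. The 2-phenylethenyl group shows that it does: in this assay the change gives a 3.7-fold higher number from compound 2 to compound 3 (0.57 log units; beyond the scatter) and a 2.3-fold higher number from compound 1 to compound 3 (0.36 log units; beyond the scatter), both modest but beyond the scatter, and compound 3 therefore stands apart from both earlier compounds, on the weaker side. Nothing available here accounts for this rise.

The compounds shown leave open whether the rise goes with the ethenyl link or with the bare phenyl ring at its end, as compound 3 differs from compound 1 and compound 2 in both respects. A plain phenyl group, a saturated 2-phenylethyl group or a 2-phenylethenyl group carrying a nitro group or a bromine on its ring would separate these two readings, and a group with no aromatic ring, such as a short alkyl chain or an amine, remains an open case at this position.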